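This account rests on a few compounds, and the source may have more. Where it says the series, first, only, none or still open, it means among the compounds named here.

Three members of the series have been measured in a functional assay on HT-29 cells (Homo sapiens) for inhibition, read by sulforhodamine B assay, with a stated time of 48 h; on this read-out lower numbers stand for stronger inhibition of growth and higher numbers for weaker inhibition of growth. Compound 1 `C=C(C)[C@@H]1CC=C(Cn2cc(COc3ccc(C4NC(=O)NC(C)=C4C(=O)OCC)cc3)nn2)CC1` gives 77100 nM. Compound 2 `C=C(C)[C@@H]1CC=C(Cn2cc(COc3cccc(C4NC(=O)NC(C)=C4C(=O)OCC)c3)nn2)CC1` gives 73400 nM in this assay. Compound 3 `C=C(C)[C@@H]1CC=C(Cn2cc(COc3ccccc3C3NC(=O)NC(C)=C3C(=O)OCC)nn2)CC1` gives > 100000 nM, which is a limit of the assay rather than a number, namely (the limit of > 100000 nM in this assay, at which 1 of the 3 values shown sits). Among the two numbers, compound 2 stands lowest, with compound 1 nearest and within the usual scatter, so no order between these two can be read.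

Compound 4 `C=C(C)[C@@H]1CC=C(Cn2cc(COc3cc(C4NC(=O)NC(C)=C4C(=O)OCC)ccc3OC)nn2)CC1` has not yet been measured in this assay. It differs from compound 2 by methoxy in place of hydrogen on an aromatic carbon. For the measured compounds named here, no step between two measured compounds isolates such a change, so the measured set gives no direction for it. The expected step is a 1.1-fold higher number from compound 2 to compound 4 (0.04 log units; within the scatter), that is, none beyond the scatter. Compound 4 is expected to give about 80000 nM in this assay, within 35000 nM to 160000 nM, with a real chance that only a limit is returned.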

Compound 4, concentration for total growth inhibition: > 100000 nM
Compound 4 ended at the assay's limit; the forecaster's own chance of this, stated with the estimate: 30%; middle value at least 1.2-fold (0.09 log units) from the limit.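

For the compounds shown here, this is the first single change that can be read: in this assay, methoxy in place of hydrogen on an aromatic carbon, ortho to a large group and para to a large group, gives an at least 1.3-fold higher number from compound 2 to compound 4 (0.13 log units; that floor lies within the scatter). That step is only a floor, and since the floor lies within the scatter, it does not establish a real loss, though it does show that methoxy at this place brings no visible gain in growth inhibition. The value of compound 4 is a limit of the assay, not a number, and this limit now holds a second member of the series: the limit of > 100000 nM in this assay, at which 2 of the 4 values shown sit.

Going by these compounds, how far compound 4 truly lies from compound 2 remains open. Also open, on these data alone, is whether an amine, a hydroxyl or a longer alkoxy chain at this place would return a number rather than a limit.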